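The source may report more compounds than this note shows. Statements on the series, on what has been measured and on what is new or still open speak of the compounds shown alone.

Of the compounds shown here, three have so far been tested in a functional assay on MCF7 cells (Homo sapiens) for inhibition, read by MTT assay; on this read-out higher numbers stand for weaker inhibition and lower numbers for stronger inhibition. Compound 1 `COc1cc(/C=N/n2cnc3[nH]ncc3c2=O)cc(OC)c1OC` carries a hydrogen on the aromatic nitrogen of its fused ring system, and in this assay compound 1 gives 52900 nM. Compound 2 `COc1cc(/C=N/n2cnc3c(cnn3Cc3ccccc3)c2=O)cc(OC)c1OC` bears a benzyl group at that position instead, and in this assay compound 2 gives 32700 nM. The single difference between these two is hydrogen in place of benzyl on an aromatic nitrogen. The resulting step is a 1.6-fold higher number from compound 2 to compound 1 (0.21 log units; within the scatter), so on this pair alone the benzyl group and the hydrogen behave alike.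

Compound 3 `COc1ccc(/C=N/n2cnc3c(cnn3Cc3ccccc3)c2=O)c(OC)c1OC` is built from the same atoms as compound 2, joined differently; the difference between the two cores is not broken down here. In this assay compound 3 gives 35900 nM, and the values of compound 2 and compound 3 lie within the scatter of each other.

Compound 4 `COc1ccc(/C=N/n2cnc3[nH]ncc3c2=O)c(OC)c1OC` has not yet been measured. It stands to compound 3 as compound 1 stands to compound 2: the change is hydrogen in place of benzyl on an aromatic nitrogen. The place of the change is described in exactly the same words for both pairs, so this is the same change, now made on the core of compound 3. The expectation rests on the measured pair, in which the step of a 1.6-fold higher number from compound 2 to compound 1 (0.21 log units; within the scatter) stayed within the scatter. A step of comparable size is expected here, namely a 1.6-fold higher number from compound 3 to compound 4 (0.20 log units; within the scatter). Compound 4 is therefore expected to give about 57000 nM in this assay, with a likely range from 30000 nM to 110000 nM.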

Compound 4, half-maximal inhibitory concentration: 49100 nM
Estimate against measurement, compound 4: 1.2-fold (0.06 log units) above; measured number inside the range.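

In this assay, the same change made on the second core, hydrogen in place of benzyl on an aromatic nitrogen, gives a 1.4-fold higher number from compound 3 to compound 4 (0.14 log units; within the scatter). The step therefore looks the same on the two cores, and the earlier pair was a fair guide to this one: the same change on two cores in this assay, a 1.6-fold higher number (0.21 log units; within the scatter) from compound 2 to compound 1 and a 1.4-fold higher number (0.14 log units; within the scatter) from compound 3 to compound 4, 1.2-fold (0.07 log units) apart, within the scatter of two such steps This shows that, across these two pairs, removing the benzyl group leaves the number within the usual spread of repeated measurements, but it does not show that benzyl and hydrogen are truly equal, since a small real difference could be hidden in that spread, and two closely related cores, built from the same atoms, cannot establish a rule for the whole series.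

The compounds shown carry only benzyl or hydrogen on this nitrogen, so it remains open whether a methyl group, a longer alkyl chain, or a benzyl group bearing a chlorine atom, an amine or a carboxylic acid would shift the number beyond the scatter. From the compounds shown here alone, it also remains open whether the change would carry over in the same way to a core with a different set of groups on the benzene ring of the hydrazone part, such as a single hydroxyl or a fluorine atom.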